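Iodo for phenyl, starting from an unreadable limit

The source may hold more compounds than are shown below. What is called first, only, known or untested is meant among the compounds shown, and "the series" means these compounds.

Compound 1 `CNc1ncnc2c1c(-c1ccccc1)cn2[C@@H]1O[C@H](CO)[C@@H](O)[C@H]1O` was tested in a functional assay on K562 cells (Homo sapiens), read by MTT assay, with a stated time of 72 h; a lower number here means a stronger inhibitor, a higher number a weaker inhibitor. In this assay compound 1 gives only a limit, > 20000 nM. Compound 2 `CSc1ncnc2c1c(-c1ccccc1)cn2[C@@H]1O[C@H](CO)[C@@H](O)[C@H]1O` likewise gives only a limit in this assay, > 20000 nM. The step that the two limits leave unreadable from compound 1 to compound 2 stays unreadable because of the limit of > 20000 nM in this assay, at which 2 of the 2 values shown sit. Compound 3 `CNc1ncnc2c1c(I)cn2[C@@H]1O[C@H](CO)[C@@H](O)[C@H]1O` differs from compound 1 by iodo in place of phenyl on an aromatic carbon. Among the measured compounds shown here, no measured step follows this change, and the one measured step gives no size or direction to carry over. Compound 3 is therefore expected to remain near the same limit, with an estimate of 30000 nM (from 8000 nM to 120000 nM), which means an expected step that the limit leaves unreadable from compound 1 to compound 3.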

Compound 3, half-maximal inhibitory concentration: > 20000 nM
Compound 3: a limit, no number; the forecaster's own chance of this, stated with the estimate: 80%; the middle value lies beyond the limit too.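

Among the compounds shown here, compound 3, like compound 1, gives only a limit, so no step between compound 1 and compound 3 can be read: the limit of > 20000 nM in this assay, at which 3 of the 3 values shown sit. As far as these compounds go, whether iodo and phenyl differ at all in this assay stays open, as does the true strength of all three compounds.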